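The source may report more compounds than this note shows. Statements on the series, on what has been measured and on what is new or still open speak of the compounds shown alone.

Working notes on the series. The shared core of compound 1 `CC(=O)Nc1ccc(S(=O)(=O)Nc2cccc(-c3nc(-c4ccc(NC(=O)c5cccnc5)cc4Cl)no3)c2)cc1` carries an arylsulfonamide on one side; in a functional assay on MDA-MB-231 cells (Homo sapiens) for antiproliferative activity, read by MTT assay, with a stated time of 72 h (a lower number here means a stronger inhibitor, a higher number a weaker inhibitor), compound 1 gives 2500 nM. Compound 2 `Cc1ccc(NC(=O)Nc2cccc(-c3nc(-c4ccc(NC(=O)c5cccnc5)cc4Cl)no3)c2)cc1` replaces the sulfonamide link with a urea to a 4-methylphenyl group, and in this assay compound 2 gives 3500 nM. The two numbers lie within the usual scatter of each other, so neither compound can be placed ahead of the other on what has been measured; compound 2 simply stands alongside compound 1.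

Compound 3 `CC(=O)Nc1ccc(NC(=O)Nc2cccc(-c3nc(-c4ccc(NC(=O)c5cccnc5)cc4Cl)no3)c2)cc1Br` keeps the urea of compound 2 and changes only the aryl group on it: 4-acetamido-3-bromophenyl in place of 4-methylphenyl on an amide-type nitrogen. For the measured compounds named here, no measured pair shows the effect of such a change, so the expectation rests on the narrow spread between compound 1 and compound 2 alone. The step from compound 2 to compound 3 in this assay is expected to be small, a 1.4-fold lower number from compound 2 to compound 3 (0.15 log units; within the scatter), in no definite direction beyond the scatter. Compound 3 is therefore estimated at 2500 nM in this assay, within a range of 900 nM to 7000 nM.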

Compound 3, half-maximal inhibitory concentration: 1000 nM
Compound 3: middle estimate off by 2.5-fold (0.40 log units), on the high side; measured number inside the range.
By their numbers in this assay, from the lowest: compound 3; then compounds 1 and 2 (each within the scatter of the next).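

The aryl group on the urea is a place where the number can move in this assay: 4-acetamido-3-bromophenyl in place of 4-methylphenyl on an amide-type nitrogen gives a 3.5-fold lower number from compound 2 to compound 3 (0.54 log units; beyond the scatter). For the compounds shown here, this is the only step that can be read, as the earlier compounds differ in more than one place and offered no measure of a change at this position alone. The change adds an acetamido group and a bromine together on the same phenyl ring, and nothing available bears on why the number falls.

The compounds shown leave open whether the acetamido group, the bromine or the two together carry the step, as neither of them stands alone on the urea in this set. Also open, as far as these compounds go, is how an amine or a carboxylic acid in place of the acetamido group would read in this assay, and whether a longer chain on that nitrogen of the acetamido group would keep the step.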